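The source may hold more compounds than are shown below. What is called first, only, known or untested is meant among the compounds shown, and "the series" means these compounds.

The study brings together three measured compounds and a fourth that awaits measurement. Compound 1 `Cc1ccc2nc(-c3ccc(NCc4cn(Cc5cc(=O)oc6cc(O)ccc56)nn4)cc3)sc2c1` was tested in a functional assay on HeLa cells (Homo sapiens) for inhibition, read by MTT assay, with a stated time of 72 h (on this read-out higher numbers stand for weaker inhibition and lower numbers for stronger inhibition), where compound 1 gives 7260 nM. Compound 2 `Cc1ccc2c(Cn3cc(CNc4ccc(-c5nc6ccc(C)cc6s5)cc4)nn3)cc(=O)oc2c1` differs from compound 1 in one place, (methyl in place of hydroxy on an aromatic carbon), and in this assay compound 2 gives 51400 nM. That single change produced a 7.1-fold higher number from compound 1 to compound 2 (0.85 log units; beyond the scatter). Compound 3 `Cn1c(-c2cn(Cc3cc(=O)oc4cc(O)ccc34)nn2)nc2ccccc21` is built on a core unlike that of compound 1, and the difference between the two cores is not broken down here. In this assay compound 3 gives 49200 nM, a number close to that of compound 2 and well apart from that of compound 1.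

Compound 4 `Cc1ccc2c(Cn3cc(-c4nc5ccccc5n4C)nn3)cc(=O)oc2c1` has not yet been measured. It differs from compound 3 by methyl in place of hydroxy on an aromatic carbon. The place is described in exactly the same words as for the change from compound 1 to compound 2, so this is the same change, occurring a second time among these compounds. For the measured compounds named here, the only guide is that one earlier step, which comes from a pair with a different core, so the transfer carries real uncertainty. For compound 4 the step is expected to be a 3.7-fold higher number from compound 3 to compound 4 (0.56 log units; beyond the scatter), because the earlier step was a 7.1-fold higher number from compound 1 to compound 2 (0.85 log units; beyond the scatter). Compound 4 is therefore estimated at 180000 nM in this assay, with a range from 50000 nM to 450000 nM. Since compound 3 already sits at the weak end, there is a fair chance that only a limit is reported.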

Compound 4, half-maximal inhibitory concentration: 17500 nM
Compound 4: the middle estimate sits 10-fold (1.01 log units) above what was measured, and the stated range ends above it.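

In this assay, putting methyl in place of hydroxy on the aromatic carbon gave a 2.8-fold lower number from compound 3 to compound 4 (0.45 log units; beyond the scatter), which means stronger inhibition on this core, whereas the same change had meant weaker inhibition on the core of compound 1, and the two steps do not agree: the same change on two cores in this assay, a 7.1-fold higher number (0.85 log units; beyond the scatter) from compound 1 to compound 2 and a 2.8-fold lower number (0.45 log units; beyond the scatter) from compound 3 to compound 4, 20-fold (1.30 log units) apart, beyond the scatter of two such steps.
In this series, then, neither the direction nor the size of the step carried over from one core to the other, so a step read on one of these cores gives no safe forecast for the other. For the compounds shown here, the result does not show why the two cores respond differently, nor which part of them matters, since they differ in more than one place and only two pairs bear on the question, and it does not establish that either hydroxy or methyl is the better group across the series.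

The compounds shown leave open how a third core would respond to this change, and whether it would follow compound 1 and compound 2 or compound 3 and compound 4. They also leave open what other groups at the same place, such as a methoxy group, an amine or a fluorine atom, would do on each of the two cores.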